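The source may hold more compounds than are shown below. What is called first, only, known or untested is meant among the compounds shown, and "the series" means these compounds.

Measured so far in a functional assay on HOS cells (Homo sapiens) for inhibition, with a stated time of 72 h; a higher number here means a weaker inhibitor, a lower number a stronger inhibitor:
- compound 1 `NC1CCC(Nc2nc(NCc3ccc(-c4ccsc4)cc3)c3ncn(C4CCCC4)c3n2)CC1`: 120 nM
- compound 2 `NC1CCC(Nc2nc(NCc3ccc(-c4ccccc4O)cc3)c3ncn(C4CCCC4)c3n2)CC1`: 1160 nM

Compound 1 holds the lower of the two numbers. Compound 3 `NC1CCC(Nc2nc(NCc3cc(Cl)ccc3O)c3ncn(C4CCCC4)c3n2)CC1` has yet to be measured in this assay. Its structural change is 5-chloro-2-hydroxyphenyl in place of 4-(thiophen-3-yl)phenyl on a saturated chain carbon bound to a nitrogen on an aromatic ring. Thus 5-chloro-2-hydroxyphenyl takes the place of the whole 4-(thiophen-3-yl)phenyl group.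

Among the compounds with values here, only one measured step bears on this, and only in part. Replacing thiophen-3-yl with 2-hydroxyphenyl gave a 9.7-fold higher number from compound 1 to compound 2 (0.99 log units; beyond the scatter), a modest loss beyond the scatter. Within the data shown here, compound 3 also loses the thiophen-3-yl and gains a hydroxy-bearing phenyl, but no measured compound carries the chlorine. A step of similar size towards a higher number is therefore expected, with wide uncertainty. The expected change is an 8.3-fold higher number from compound 1 to compound 3 (0.92 log units; beyond the scatter). For compound 3 the estimated value is 1000 nM, with an expected range of 300 nM to 3500 nM.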

Compound 3, half-maximal inhibitory concentration: 490 nM
The estimate for compound 3 lay 2.0-fold (0.31 log units) above the measured number, within the range that was stated.
By their numbers in this assay, from the lowest: compound 1; then compound 3; then compound 2.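

In this assay, the step at this position is a 4.1-fold higher number from compound 1 to compound 3 (0.61 log units; beyond the scatter), so replacing the whole 4-(thiophen-3-yl)phenyl group costs some inhibition, and the size of that loss is modest. The change leaves a single six-membered aromatic ring of carbon only on the saturated chain carbon, and compound 3 still gives 490 nM, so within this pair the thiophene ring is not required for a measurable inhibitory effect. Nothing available accounts for the size of this step.

The separate contributions of the chlorine and the hydroxy group remain open, as the two enter together in compound 3 and no compound shown carries either alone on this single ring. Analogues with a methoxy group in place of the hydroxy group, or with fluorine or a methyl group in place of the chlorine, would help to separate them.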